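The source may report more compounds than this note shows. Statements on the series, on what has been measured and on what is new or still open speak of the compounds shown alone.

Four compounds share one core. Compound 1 `Nc1nc(-c2ccccn2)nn1-c1ncnc2cc(N3CCNCC3)c([N+](=O)[O-])cc12`, compound 2 `COc1cc2c(-n3nc(-c4ccccn4)nc3N)ncnc2cc1OCc1ccccc1` and compound 3 `COc1cc2ncnc(-n3nc(-c4ccccn4)nc3N)c2cc1OCCCN1CC(C)OC(C)C1` have been measured in an assay on MCF7 cells for inhibition of Serine-protein kinase ATM (Homo sapiens), read by immunofluorescence, with a stated time of 1 h (on this read-out lower numbers stand for stronger inhibition and higher numbers for weaker inhibition), while compound 4 `CCCCCCOC(=O)NCCCOc1cc2c(-n3nc(-c4ccccn4)nc3N)ncnc2cc1OC` has not. In this assay compound 1 gives > 40000 nM, which is a limit of the assay and not a number. Compound 2 gives > 40000 nM, again a limit rather than a number. Within the data shown here, compound 3 gives 1600 nM and so stands as the only member of the set with a measured number; the other two values sit at the limit of > 40000 nM in this assay, at which 2 of the 3 values shown sit. Among the measured compounds shown here, no step between two measured compounds exists here, so the move to compound 4 rests on the structural change alone. Compound 4 differs from compound 3 by (hexyloxycarbonyl)amino in place of 2,6-dimethylmorpholin-4-yl on a saturated chain carbon, three bonds along the chain from an oxygen on an aromatic ring, a saturated ring giving way to an open chain carrying a carbamate. A step of modest size toward weaker inhibition is expected from compound 3 to compound 4, a 1.9-fold higher number from compound 3 to compound 4 (0.27 log units; within the scatter), though an outcome within the scatter of compound 3 cannot be ruled out. Compound 4 is accordingly estimated at 3000 nM, with a range from 800 nM to 15000 nM.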

Compound 4, half-maximal inhibitory concentration: 28600 nM
The estimate for compound 4 lay 9.5-fold (0.98 log units) below the measured number; the measured number lies above the stated range.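

At the saturated chain carbon, three bonds along the chain from an oxygen on an aromatic ring, this assay proves sensitive to the end group: (hexyloxycarbonyl)amino in place of 2,6-dimethylmorpholin-4-yl gives an 18-fold higher number from compound 3 to compound 4 (1.25 log units; beyond the scatter) in the first comparison the set allows. A saturated ring giving way to an open chain carrying a carbamate is therefore not a neutral change at this position, and the size of the step lies beyond the scatter. Compound 1 and compound 2 remain limits of the assay and not numbers: the limit of > 40000 nM in this assay, at which 2 of the 4 values shown sit.

From the compounds shown here alone, the step replaces the ring and brings in both the carbamate and the hexyl chain, and which of these carries the loss stays open. A butyl carbamate, a plain primary amine or an unsubstituted morpholine on the same chain would separate them.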